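Benzyl oxime ethers: halogenation of the benzyl group

The source may hold more compounds than are shown below. What is called first, only, known or untested is meant among the compounds shown, and "the series" means these compounds.

Measured so far:
compound 1 `c1ccc(CO/N=C2/C(c3c[nH]c4ccccc34)=Nc3ccccc32)cc1`, 16900 nM
compound 2 `Fc1ccc2c(c1)/C(=N\OCc1ccccc1)C(c1c[nH]c3ccc(F)cc13)=N2`, 12300 nM
compound 3 `Clc1cccc(CO/N=C2/C(c3c[nH]c4ccc(Br)cc34)=Nc3ccc(Br)cc32)c1`, 14100 nM

In a functional assay on SK-OV-3 cells (Homo sapiens) for cytotoxicity, read by MTT assay, with a stated time of 2 days (on this read-out lower numbers stand for stronger inhibition and higher numbers for weaker inhibition), compound 1 gives 16900 nM, the highest of the three numbers, yet its gaps to compound 3 and to compound 2 both sit within the usual scatter, so no order among the three can be read. Compound 4 `Fc1ccc(CO/N=C2/C(c3c[nH]c4ccccc34)=Nc3ccccc32)c(Cl)c1` differs from compound 1 by 2-chloro-4-fluorophenyl in place of phenyl on a saturated chain carbon bound to an oxygen on an unsaturated carbon. Among the measured compounds shown here, no pair of measured compounds isolates this change; compound 2 and compound 3 vary at the shared core rather than at the benzyl group, and their numbers stay within scatter of compound 1. The step from compound 1 to compound 4 is therefore estimated at a 1.2-fold lower number from compound 1 to compound 4 (0.08 log units; within the scatter), with no direction beyond the scatter. Compound 4 is expected near 14000 nM, within 6000 nM to 35000 nM.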

Compound 4, half-maximal inhibitory concentration: 37600 nM
For compound 4 the middle estimate is 2.7-fold (0.43 log units) below the measured one; the measured number lies above the stated range.
By their numbers in this assay, from the lowest: compounds 2, 3 and 1 (each within the scatter of the next); then compound 4.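

In this assay, 2-chloro-4-fluorobenzyl in place of benzyl gives a 2.2-fold higher number from compound 1 to compound 4 (0.35 log units; beyond the scatter), so this position on the benzyl group is not indifferent to substitution, and this change moves towards weaker inhibition. Among the compounds shown here, it is the only step that can be read so far, and it rests on a single pair. Nothing on hand accounts for this step.

The chlorine and the fluorine enter together in compound 4, leaving their separate contributions open. On these data alone, how a methoxy group or an amine on the benzyl ring would read here also remains open.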